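The source may report more compounds than this note shows. Statements on the series, on what has been measured and on what is new or still open speak of the compounds shown alone.

Working notes on the series. Two compounds of the shared core carry numbers in a functional assay on cells (Leukemia cell, Homo sapiens) for cytotoxicity, read by sulforhodamine B assay, with a stated time of 48 h; a lower number here means a stronger inhibitor of growth, a higher number a weaker inhibitor of growth. Compound 1 `COc1ccc(C2CC(c3ccccc3)=NN2C2=NC(=O)/C(=C3\C(=O)Nc4ccccc43)S2)cc1` gives 1640 nM in this assay. Compound 2 `O=C1N=C(N2N=C(c3ccccc3)CC2c2ccc(Cl)cc2)S/C1=C1/C(=O)Nc2ccccc21` gives 370 nM in this assay. Among the measured compounds shown here, the one measured step, a 4.4-fold lower number from compound 1 to compound 2 (0.65 log units; beyond the scatter), is the only comparison so far. Compound 2 therefore stands with the lowest number of the two, its nearest neighbour being compound 1 with the higher value.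

Compound 3 `Cc1ccc2c(c1)/C(=C1\SC(N3N=C(c4ccccc4)CC3c3ccc(Cl)cc3)=NC1=O)C(=O)N2` is not yet measured. It differs from compound 2 by methyl in place of hydrogen on an aromatic carbon. For the measured compounds named here, the one measured step concerns a different ring of the core and a different kind of exchange, so it offers no direct precedent for this change; no step bears on it. With nothing to point either way, the expected change in this assay from compound 2 to compound 3 is a 1.1-fold higher number from compound 2 to compound 3 (0.03 log units; within the scatter), that is, none beyond the scatter. Compound 3 is estimated at 400 nM, with a range of 150 nM to 1100 nM.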

Compound 3, concentration for 50% growth inhibition: 390 nM
For compound 3 the middle estimate is 1.0-fold (0.01 log units) above the measured one; the measured number falls inside the stated range.
By their numbers in this assay, from the lowest: compounds 2 and 3 (each within the scatter of the next); then compound 1.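

Methyl in place of hydrogen on this aromatic carbon gives a 1.1-fold higher number from compound 2 to compound 3 (0.02 log units; within the scatter) in this assay. Among the compounds shown here, this is the first reading on the six-membered aromatic ring of carbon only in the fused system of two rings, as the earlier step concerned a different ring of the core; with the chloro group held constant, a single added carbon here leaves compound 2 and compound 3 within the scatter of each other. No further data bear on the reason for this result.

On these data alone, whether an amine, a carboxylic acid or a longer chain on this same carbon would also stay within the scatter remains open. Also open, as far as these compounds go, is whether the methyl exchange would read the same with methoxy in place of chloro, as in compound 1.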